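This account rests on a few compounds, and the source may have more. Where it says the series, first, only, none or still open, it means among the compounds named here.

Measured so far in an assay on a protein complex for inhibition of ubiquitin carboxyl-terminal hydrolase 1/WD repeat-containing protein 48 (Homo sapiens), read by fluorescence; a lower number here means a stronger inhibitor, a higher number a weaker inhibitor:
- compound 1, `Cc1cnc(-c2ccccc2C(C)C)nc1NCc1cccs1`: 270 nM
- compound 2, `Cc1cnc(-c2ccccc2C(C)C)nc1NCC1CCN(C)CC1`: "not active" (no number reported)

Going by the values given here, compound 2 stands without a single number in this assay; it is recorded only as inactive, so no step from it to any other compound can be sized. Among the compounds with values here, compound 1 is the only member with a measured half-maximal inhibitory concentration, and in this assay compound 1 gives 270 nM.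

The next compound, compound 3, `Cc1ccc(N2CCC(CNc3nc(-c4ccccc4C(C)C)ncc3C)CC2)cn1`, differs from compound 2 in one place: 6-methylpyridin-3-yl in place of methyl on an amine nitrogen in a ring. An aromatic ring enters where compound 2 carried only a methyl on the amine nitrogen in the ring. With no numeric starting point for compound 2, no step size can be expected in either direction beyond what the two structures show. Taking compound 1, which carries an aromatic ring in a related position and gives 270 nM, as the only anchor, compound 3 is expected to fall near 1500 nM, within a range from 200 nM to 12000 nM.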

Compound 3, half-maximal inhibitory concentration: 90 nM
For compound 3 the middle estimate is 17-fold (1.22 log units) above the measured one; the measured number lies below the stated range.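

In this assay, going by these compounds alone, compound 2 has no number, so no step to compound 3 can be read. The compounds shown leave open how much the 6-methylpyridin-3-yl group contributes, as no compound with a number differs from compound 3 in one place. No evidence bears on this result.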